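The source may hold more compounds than are shown below. What is called first, only, known or untested is meant among the compounds shown, and "the series" means these compounds.

Of the compounds shown here, three built on a shared core have been measured in an assay for inhibition of high affinity nerve growth factor receptor (Homo sapiens), read by HTRF, with a stated time of 30 min, in the presence of a further agent that is not named here; on this read-out higher numbers stand for weaker inhibition and lower numbers for stronger inhibition. Compound 1, `Cc1cc(Nc2nc(NCc3ccc(Cl)cc3)nc3ccccc23)n[nH]1`, gives 380 nM. Compound 2, `Cc1ccc(CNc2nc(Nc3cc(C)[nH]n3)c3ccccc3n2)cc1`, gives 110 nM. Compound 3, `Cc1cc(Nc2nc(NCc3ccc(F)cc3F)nc3ccc(Cl)cc23)n[nH]1`, gives 520 nM, the highest of the three numbers; its gap to compound 1 lies within the scatter, while its gap to compound 2 lies beyond it. Compound 1 and compound 2 differ in one place, (methyl in place of chloro on an aromatic carbon), and that change gave a modest step, a 3.5-fold lower number from compound 1 to compound 2 (0.54 log units; beyond the scatter). The difference between the core of compound 1 and the core of compound 3 is not broken down here.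

Compound 4, `Cc1ccc2nc(NCc3ccc(F)cc3F)nc(Nc3cc(C)[nH]n3)c2c1`, has not yet been measured in this assay. It differs from compound 3 by methyl in place of chloro on an aromatic carbon. Within the data shown here, this is the same kind of change as the one from compound 1 to compound 2, but not the same: in compound 2 the methyl stands on a six-membered aromatic ring of carbon only, para to a large group, whereas in compound 4 it stands on a six-membered aromatic ring of carbon only that is part of a fused or bridged system of two rings, meta to a fused ring and para to a fused ring. Because a 3.5-fold lower number from compound 1 to compound 2 (0.54 log units; beyond the scatter) was modest and was made at another place, only a smaller step is expected here, a 1.7-fold lower number from compound 3 to compound 4 (0.24 log units; within the scatter). Compound 4 is therefore expected to give about 300 nM, with a likely range from 100 nM to 900 nM.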

Compound 4, half-maximal inhibitory concentration: 110 nM
The estimate for compound 4 lay 2.7-fold (0.44 log units) above the measured number, within the range that was stated.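

In this assay, methyl in place of chloro on an aromatic carbon gave a 4.7-fold lower number from compound 3 to compound 4 (0.67 log units; beyond the scatter) and so again moved the number down by more than the scatter, and this step can be set beside the earlier one: the same change on two cores in this assay, a 3.5-fold lower number (0.54 log units; beyond the scatter) from compound 1 to compound 2 and a 4.7-fold lower number (0.67 log units; beyond the scatter) from compound 3 to compound 4, 1.4-fold (0.14 log units) apart, within the scatter of two such steps. The change therefore carried over from one core to the other with no difference in size that can be told apart, even though it stood at a different place in each pair, on the ring that is part of a fused system in compound 4 and on a separate six-membered aromatic ring of carbon only in compound 2. This does not show a rule for the whole series, as it rests on two pairs in a single assay, and it says nothing about why the number falls.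

The compounds shown leave open how a methoxy group, a nitrile or an amine would compare with methyl and chloro at either place, and whether a longer chain such as ethyl would continue the step seen with methyl. They also leave open whether the two steps would add up in one compound carrying methyl at both places.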